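The source may hold more compounds than are shown below. What is called first, only, known or untested is meant among the compounds shown, and "the series" means these compounds.

Series notes, compound 4 pending.

Three compounds of the shared core have numbers in a functional assay on cells for antagonist activity at C-X-C chemokine receptor type 4 (Homo sapiens), read by fluorescence and calcium flux, with stated times of 25 min and 90 s; on this read-out higher numbers stand for weaker inhibition and lower numbers for stronger inhibition. Compound 1, `c1ccc2c(c1)CN[C@@H](CN(CCCCN(Cc1ccncc1)Cc1ccncc1)[C@H]1CCCc3cccnc31)C2`, gives 832 nM in this assay. Compound 2, `c1ccc2c(c1)CN[C@@H](CN(CCCCNCC1CCCCC1)[C@H]1CCCc3cccnc31)C2`, gives 158 nM. Compound 3, `c1ccc2c(c1)CN[C@@H](CN(Cc1ccc(CNCc3ccncc3)cc1)[C@H]1CCCc3cccnc31)C2`, gives 134 nM. On these numbers compound 2 stands second highest of the three: its nearest neighbour is compound 3, whose number lies within the scatter of that of compound 2, so no order between the two is claimed; its furthest is compound 1, whose number lies beyond the scatter and is the higher one.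

The next compound, compound 4, is `C(=C/CN(C[C@H]1Cc2ccccc2CN1)[C@H]1CCCc2cccnc21)\CNCC1CCOCC1`. Against compound 2 the change is a group of 11 heavy atoms (9 carbon, 1 nitrogen, 1 oxygen; one six-membered non-aromatic ring with 1 hetero atom) in place of a group of 11 heavy atoms (10 carbon, 1 nitrogen; one six-membered non-aromatic ring of carbon only), on a saturated chain carbon bound to an amine nitrogen. The leaving group is the 3-((cyclohexylmethyl)amino)propyl of compound 2; the entering group carries one six-membered non-aromatic ring with 1 hetero atom and 1 double bond outside aromatic rings. No measured pair in the set differs at this place alone, so there is no shown step to rest on; the numbers for compound 1, compound 2 and compound 3 merely show the span the core tolerates so far.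

The expectation for the change from compound 2 to compound 4 in this assay is a small step, a 1.6-fold higher number from compound 2 to compound 4 (0.20 log units; within the scatter), most likely toward a somewhat higher number and not clearly beyond the scatter. Compound 4 is therefore estimated at 250 nM in this assay, with a range from 80 nM to 800 nM.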

Compound 4, half-maximal inhibitory concentration: 24.2 nM
For compound 4 the middle estimate is 10-fold (1.01 log units) above the measured one; the measured number lies below the stated range.
By their numbers in this assay, from the lowest: compound 4; then compounds 3 and 2 (each within the scatter of the next); then compound 1.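

Among these compounds, this is the first readable step at this place, on a saturated chain carbon bound to an amine nitrogen; the earlier compounds gave only a span of numbers for the shared core, whereas in this assay this exchange gives a 6.5-fold lower number from compound 2 to compound 4 (0.81 log units; beyond the scatter). The step comes with the size of the group held at 11 heavy atoms and 1 hydrogen-bond donor; what differs is one carbon fewer, one oxygen in the six-membered non-aromatic ring, 1 double bond outside aromatic rings, and 2 hydrogen-bond acceptors where the leaving group has 1. Nothing at hand gives a measured reason for the step.

The step carries the ring oxygen and the double bond together, and the compounds shown do not separate them, so how much of it belongs to either remains open. Also open, on these data alone, is how a longer chain, or a ring with an amine nitrogen in place of the oxygen, would read in this assay at this place.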